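Trimethoxyphenyl in place of phenyl on the five-membered ring

The compounds below may be only part of what the source reports. "The series", "measured", "known", "first", "only" and "open" are said of these compounds alone.

Among the compounds with values here, compound 3 `COc1cc(/C=C/C(=O)c2cccc(-n3cc(-c4ccccc4)[nH]c3=O)c2)cc(OC)c1OC` gives 620 nM in a functional assay on RPMI8266 cells (Homo sapiens) for inhibition (on this read-out lower numbers stand for stronger inhibition of growth and higher numbers for weaker inhibition of growth), and stands lowest of the three numbers measured so far, with both other compounds beyond the scatter from it. Compound 2 `O=C(/C=C/c1cccc(O)c1)c1cccc(-n2cc(-c3ccccc3)[nH]c2=O)c1` gives 2150 nM in this assay, and compound 1 `COc1cc(/C=C/C(=O)c2cccc(-n3cc(-c4ccc(Cl)cc4)[nH]c3=O)c2)cc(OC)c1OC` gives 3920 nM.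

Compound 4 `COc1cc(/C=C/C(=O)c2cccc(-n3cc(-c4cc(OC)c(OC)c(OC)c4)[nH]c3=O)c2)cc(OC)c1OC` differs from compound 3 by 3,4,5-trimethoxyphenyl in place of phenyl on an aromatic carbon. Within the data shown here, the only measured step at this phenyl is a 6.3-fold lower number from compound 1 to compound 3 (0.80 log units; beyond the scatter), so the one substituent tried on this ring so far, a chloro, gave the higher number, and its removal gave the lower one. Compound 2 and compound 3 differ at another place and offer no guide to this change. Among the measured compounds shown here, three methoxy groups are a larger change than one chloro, and no step of this kind has been measured, so the direction rests on the single chloro step only and the uncertainty is wide. For compound 4 the expected value is 1500 nM, with a range of 400 nM to 6000 nM. This estimate means an expected step of a 2.4-fold higher number from compound 3 to compound 4 (0.38 log units; beyond the scatter).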

Compound 4, concentration for 50% growth inhibition: 230 nM
For compound 4 the middle estimate is 6.5-fold (0.81 log units) above the measured one, outside the stated range (below it).
By their numbers in this assay, from the lowest: compound 4; then compound 3; then compounds 2 and 1 (each within the scatter of the next).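

In this assay, a substituent on this phenyl ring is not in itself a loss: 3,4,5-trimethoxyphenyl in place of phenyl gives a 2.7-fold lower number from compound 3 to compound 4 (0.43 log units; beyond the scatter), so the higher number seen with the chloro group does not extend to every substituted ring at this place. Set against 4-chlorophenyl, the same group gives a 17-fold lower number from compound 1 to compound 4 (1.23 log units; beyond the scatter), the largest step shown at this position, so the identity of the substituents on this ring weighs more here than their mere presence. Nothing shown accounts for this difference between the two substituted rings.

It remains open whether all three methoxy groups are needed, as a single methoxy group or a 3,5-dimethoxyphenyl group is not among the compounds shown. Also open, on these data alone, is how an amine or a carboxylic acid on this ring would read in this assay.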